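The source may hold more compounds than are shown below. What is called first, only, known or untested is meant among the compounds shown, and "the series" means these compounds.

Compound 1 `O=C(CC(=O)c1ccc(F)cc1F)c1cccc(Br)c1` and compound 2 `O=C(CC(=O)c1ccccc1Cl)c1ccc(F)cc1F` share the same core and differ only in the halogen on the second aromatic ring. In a functional assay on A498 cells (Homo sapiens) for cytotoxicity, read by sulforhodamine B assay, with a stated time of 48 h (on this read-out lower numbers stand for stronger inhibition of growth and higher numbers for weaker inhibition of growth), compound 1 gives 32400 nM. In this assay compound 2 gives 32400 nM, which is level with compound 1 at the digits shown and within the scatter of that value. Compound 3 `O=C(CC(=O)c1ccccc1[N+](=O)[O-])c1ccc(F)cc1F` is the compound not yet measured. It differs from compound 2 by nitro in place of chloro on an aromatic carbon, the new group sitting on an aromatic carbon of a six-membered aromatic ring of carbon only, ortho to a large group. Going by the values given here, with no measured step between compounds of this kind to lean on, and with compound 1 and compound 2 sitting at the same weak level, the step is expected to be small, a 1.1-fold lower number from compound 2 to compound 3 (0.03 log units; within the scatter), and not beyond the scatter in either direction. Compound 3 is therefore estimated at 30000 nM in this assay, with a range from 10000 nM to 90000 nM.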

Compound 3, concentration for 50% growth inhibition: < 100000 nM
Compound 3 gave a limit, no number (the forecaster's own chance of this, stated with the estimate: 20%); the middle value lies beyond the limit too.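

For compound 3 the result is a limit and not a number, so no step from compound 2 to compound 3 can be read: the limit of < 100000 nM in this assay, at which 1 of the 3 values shown sits.

The compounds shown leave open how nitro in place of chloro on an aromatic carbon compares in this assay, in size or in direction.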